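The compounds below may be only part of what the source reports. "The series", "measured", "known", "first", "only" and "open" are said of these compounds alone.

Compound 1 `CC1=NN(S(=O)(=O)c2ccc([N+](=O)[O-])cc2)C(c2cc(Br)ccc2O)C1` and compound 2 `CC1=NN(S(=O)(=O)c2ccc(F)cc2)C(c2cc(Br)ccc2O)C1` share one core and differ in the group on the sulfonyl sulfur. In a functional assay on SGC-7901 cells (Homo sapiens) for antiproliferative activity, read by MTT assay, with a stated time of 48 h (on this read-out lower numbers stand for an effect already at smaller amounts and higher numbers for an effect only at larger amounts of compound), compound 1 gives 27300 nM. Compound 2 gives > 60000 nM, which is a limit and not a number. Compound 2 therefore stands at the limit of > 60000 nM in this assay, at which 1 of the 2 values shown sits. Compound 3 `CC1=NN(S(=O)(=O)c2ccc(Cl)cc2Cl)C(c2cc(Br)ccc2O)C1` keeps the core and changes that group again: 2,4-dichlorophenyl in place of 4-fluorophenyl on a sulfonyl sulfur. For the measured compounds named here, only one measured step bears on this change, an at least 2.1-fold higher number from compound 1 to compound 2 (0.34 log units; beyond the scatter), and it lies beyond the scatter. Going by the values given here, no measured compound carries chlorine, so this step gives the direction only loosely. Among the compounds with values here, compound 1, at 27300 nM, is the only firm number in this assay and anchors the expectation. A modest move toward lower numbers is expected, an at least 1.5-fold lower number from compound 2 to compound 3 (0.19 log units; that floor lies within the scatter). For compound 3 the estimated value is 38000 nM, with an expected range from 14000 nM to 80000 nM.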

Compound 3, half-maximal effective concentration: > 60000 nM
Compound 3 was reported as a limit; the forecaster's own chance of this, stated with the estimate: 40%; middle value at least 1.5-fold (0.19 log units) away from the limit.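

In this assay compound 3, like compound 2, is reported only as a limit, so no step between the two can be read: the limit of > 60000 nM in this assay, at which 2 of the 3 values shown sit.

The compounds shown leave open which of the 4-fluorophenyl and 2,4-dichlorophenyl groups goes with the lower number, and how far either compound lies beyond that limit.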